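The compounds below may be only part of what the source reports. "The series", "measured", "known", "first", "only" and "open" are said of these compounds alone.

Compound 1, `COc1ccccc1C(=O)N(C)O`: in an ADME assay on Huh-7 cells (Homo sapiens) for cytotoxicity, read by MTT assay, with a stated time of 72 h (on this read-out lower numbers stand for higher toxicity in this test and higher numbers for lower toxicity in this test), compound 1 gives > 800000 nM, which is a limit of the test and not a number.
Compound 2, `CONC(=O)c1ccccc1`: in this assay compound 2 gives > 800000 nM, again a limit.
Compound 3, `CONC(=O)c1ccccc1O`: in this assay compound 3 gives > 800000 nM, also a limit.

Compound 3 therefore stands on a limit only, and so do the other two compounds: every value shown sits at the limit of > 800000 nM in this assay, at which 3 of the 3 values shown sit. Among the compounds with values here, the single measured step, a step that the two limits leave unreadable from compound 2 to compound 3, is for that reason unreadable in size and direction.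

Compound 4 is `CONC(=O)c1ccccc1OC`. It differs from compound 3 by methyl in place of hydrogen on an oxygen on an aromatic ring. Within the data shown here, no measured step matches this change, and the one step that exists between the measured compounds cannot be read, so there is no measured guide to the size of the step to expect in this assay.

Given that compound 3 and both other compounds reach only the limit, compound 4 is expected to behave the same way, with a step that the limit leaves unreadable from compound 3 to compound 4 expected to lie within the usual scatter. The estimate for compound 4 is 1200000 nM, with a range from 400000 nM to 4000000 nM, and most likely the test will again report only a limit.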

Compound 4, half-maximal cytotoxic concentration: > 800000 nM
Compound 4 gave a limit, no number (the forecaster's own chance of this, stated with the estimate: 85%); the middle value lies beyond the limit too.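

The steps to compound 4 from compound 1, compound 2 and compound 3 cannot be read, because each compares two limits and not two numbers: the limit of > 800000 nM in this assay, at which 4 of the 4 values shown sit. The compounds shown leave open at what concentration, if any, these four compounds would harm the cells in this assay, and whether any change to the shared core would alter that.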